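Adding a methylpiperidine to a pyrazole-bearing inhibitor

The compounds below may be only part of what the source reports. "The series", "measured", "known", "first", "only" and "open" are said of these compounds alone.

Going by the values given here, compound 3 `Cc1ccc(C(=O)Nc2cccc(C(F)(F)F)c2)cc1-c1ccc2c(-c3cn[nH]c3)n[nH]c2c1` is one of three compounds measured in an assay on isolated protein for inhibition of Discoidin domain-containing receptor 2 (Homo sapiens), read by ELISA, with a stated time of 60 min; a lower number here means a stronger inhibitor, a higher number a weaker inhibitor. In this assay compound 3 gives 55.6 nM, the highest number of the three and beyond the scatter from both of the others. Compound 1 `Cc1ccc(C(=O)Nc2cc(CN3CCN(C4CCCC4)CC3)cc(C(F)(F)F)c2)cc1-c1ccc2cn[nH]c2c1` gives 7 nM, and compound 2 `Cc1ccc(C(=O)Nc2cccc(C(F)(F)F)c2)cc1-c1ccc2c(-c3ccc(CN4CCN(C)CC4)cc3)n[nH]c2c1` gives 6.2 nM. The next compound, compound 4 `Cc1ccc(C(=O)Nc2cccc(C(F)(F)F)c2)cc1-c1ccc2c(-c3cnn(C4CCN(C)CC4)c3)n[nH]c2c1`, is built from compound 3 by a single change: 1-methylpiperidin-4-yl in place of hydrogen on an aromatic nitrogen. Among the compounds with values here, no measured pair shows this exact change. Still, compound 2 also carries a large nitrogen-containing group on the shared core and gives 6.2 nM, so for compound 4 a step toward stronger inhibition is expected, estimated as a 6.2-fold lower number from compound 3 to compound 4 (0.79 log units; beyond the scatter). Compound 4 is therefore expected to give about 9 nM, between 3 nM and 30 nM.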

Compound 4, half-maximal inhibitory concentration: 3.8 nM
The estimate for compound 4 lay 2.4-fold (0.37 log units) above the measured number; the range from low to high includes it.
By their numbers in this assay, from the lowest: compounds 4, 2 and 1 (each within the scatter of the next); then compound 3.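

In this assay, the aromatic nitrogen of the pyrazole in compound 3 accepts a large substituent: 1-methylpiperidin-4-yl in place of hydrogen gives a 15-fold lower number from compound 3 to compound 4 (1.17 log units; beyond the scatter), the first step read directly at this position. The hydrogen on this nitrogen is therefore not required for inhibition in this series. The compounds shown offer no measured explanation for the size of this step. From the compounds shown here alone, whether the step depends on the ring nitrogen of the 1-methylpiperidin-4-yl group remains open, as a cyclohexyl ring or a simple methyl group on the same aromatic nitrogen would be needed to separate the ring from the amine.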